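The source may hold more compounds than are shown below. What is called first, only, known or untested is meant among the compounds shown, and "the series" means these compounds.

Measured so far:
compound 1 `CN1C(=O)C2ON=C(c3cn(-c4ccccc4)nc3-c3ccccc3)C2C1=O`, giving 30.6% in a functional assay on the whole organism (Abdomen, strain Swiss albino) with Mus musculus as the target, with stated times of 10 min and 5 min, at a dose of 30 mg/kg by the oral route; on this read-out higher numbers stand for a stronger effect at the one dose given and lower numbers for a weaker effect
compound 2 `CN1C(=O)C2ON=C(c3cn(-c4ccccc4)nc3-c3ccc(Br)cc3)C2C1=O`, giving 40.4% in this assay
compound 3 `CCOC(=O)c1onc(-c2cn(-c3ccccc3)nc2-c2ccc(Br)cc2)c1C(=O)OCC`, giving 56.9% in this assay

Compound 3 stands highest of the three numbers; compound 2 lies nearest and compound 1 furthest, both gaps beyond the scatter. The next step goes from compound 3 to compound 4 `CCOC(=O)c1onc(-c2cn(-c3ccccc3)nc2-c2ccc(Cl)cc2)c1C(=O)OCC`, not yet measured: chloro in place of bromo on an aromatic carbon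

Among the compounds with values here, no measured step swaps one halogen for another. Within the data shown here, the only step at this position, a number 9.8 percentage points higher from compound 1 to compound 2 (within the scatter), stayed within the scatter, so a halogen change at the same place is expected to move the number little, with no step beyond the scatter anticipated: a number 4.9 percentage points lower from compound 3 to compound 4 (within the scatter). Compound 4 is therefore estimated at 52%, with a range of 38% to 66%.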

Compound 4, a percentage reported as activity, at one dose (the size of the read-out at that dose, not a potency): 55.3%
Compound 4: middle estimate off by 3.3 percentage points, on the low side, and the stated range covers the measured number.
By their numbers in this assay, from the lowest: compounds 1 and 2 (each within the scatter of the next); then compounds 4 and 3 (each within the scatter of the next).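

Unlike the earlier step at this position, this one exchanges one halogen for another: in this assay, 4-bromophenyl to 4-chlorophenyl gives a number 1.6 percentage points lower from compound 3 to compound 4 (within the scatter). On the core of compound 3, this read-out therefore does not separate bromo from chloro on this aromatic carbon. Nothing available bears on what lies behind this result.

Still open, as far as these compounds go, is whether fluoro, methoxy or an amine on the same aromatic carbon would read alike. Also open, from the compounds shown here alone, is whether plain hydrogen there would hold the number on the core of compound 3.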